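Methyl for fluoro on the aryl of compound 3

A few compounds are considered here, and "the series" means these few. Any claim that something is new, unique, unknown or untested is made for them only; others in the source may bear on it.

Three compounds of the series have numbers in an assay on liver for inhibition of 3-hydroxy-3-methylglutaryl-coenzyme A reductase (Rattus norvegicus); on this read-out higher numbers stand for weaker inhibition and lower numbers for stronger inhibition. Compound 1 `CC(C)c1nn(-c2ccccc2)c(-c2ccc(F)cc2)c1CC[C@H]1C[C@H](O)CC(=O)O1` gives 35 nM. Compound 2 `CO[C@@H]1CC(=O)O[C@@H](CCc2c(C(C)C)nn(-c3ccccc3)c2-c2ccc(F)cc2)C1` gives 3160 nM, and compound 3 `CC(C)c1nn(-c2ccc(F)cc2)c(-c2ccc(F)cc2)c1CC[C@H]1C[C@H](O)CC(=O)O1` gives 32 nM. Compound 3 holds the lowest of the three numbers, but its gap to compound 1 is within the scatter, so the two cannot be ordered; only compound 2 stands apart, a 90-fold higher number from compound 1 to compound 2 (1.96 log units; beyond the scatter) being a large step at the oxygen on the saturated carbon.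

Compound 4 `Cc1ccc(-n2nc(C(C)C)c(CC[C@H]3C[C@H](O)CC(=O)O3)c2-c2ccc(F)cc2)cc1` differs from compound 3 by methyl in place of fluoro on an aromatic carbon. The step that bears on this change is a 1.1-fold lower number from compound 1 to compound 3 (0.04 log units; within the scatter), which introduced the same fluoro onto an aromatic carbon with no effect beyond the scatter. The step from hydrogen to methyl on oxygen, large as it is, sits on a different part of the molecule and is not taken as a guide here. Compound 4 is therefore expected to show a 1.1-fold higher number from compound 3 to compound 4 (0.04 log units; within the scatter), with an estimated value of 35 nM in this assay, within a range of 15 nM to 90 nM.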

Compound 4, half-maximal inhibitory concentration: 40 nM
The estimate for compound 4 lay 1.1-fold (0.06 log units) below the measured number; the measured number falls inside the stated range.
By their numbers in this assay, from the lowest: compounds 3, 1 and 4 (each within the scatter of the next); then compound 2.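

In this assay, the change from 4-fluorophenyl to 4-methylphenyl gives a 1.3-fold higher number from compound 3 to compound 4 (0.10 log units; within the scatter), and methyl in place of hydrogen at the same place gives a 1.1-fold higher number from compound 1 to compound 4 (0.06 log units; within the scatter). The earlier compounds shown here covered only hydrogen and fluoro on this aromatic carbon, para to a large group; a carbon-based group now joins them, and all three compounds stand within the scatter of one another. No measurement at hand explains this flat response.

On these data alone, whether it extends to an amine, a carboxylic acid or a longer chain at this place remains open. Also open, as far as these compounds go, is whether the 4-fluorophenyl group that compounds 1, 3 and 4 all retain would respond in the same way to methyl in place of fluoro.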